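This account rests on a few compounds, and the source may have more. Where it says the series, first, only, none or still open, it means among the compounds named here.

Working notes on the series. In a functional assay on HeLa cells (Homo sapiens) for cytotoxicity, read by MTT assay (a lower number here means a stronger inhibitor, a higher number a weaker inhibitor), compound 1 `CC1=NNC(=O)C1C(c1c(-c2ccccc2)[nH]c2ccc(C)cc12)c1c(-c2ccccc2)[nH]c2ccc(C)cc12` gives 32700 nM. Compound 2 `COc1ccc2[nH]c(-c3ccccc3)c(C(c3c(-c4ccccc4)[nH]c4ccc(C)cc34)C3C(=O)NN=C3C)c2c1` gives only a limit of the assay, > 100000 nM. Among the compounds with values here, the one measured step, an at least 3.0-fold higher number from compound 1 to compound 2 (0.48 log units; beyond the scatter), rests on (the limit of > 100000 nM in this assay, at which 1 of the 2 values shown sits), so compound 2 stands at the weaker end of the two numbers. Compound 3 `CC1=NNC(=O)C1C(c1c(-c2ccccc2)[nH]c2ccccc12)c1c(-c2ccccc2)[nH]c2ccc(C)cc12` differs from compound 2 by hydrogen in place of methoxy on an aromatic carbon; hydrogen in place of methoxy on an aromatic carbon. This removes the group whose entry raised the number, so a modest fall is expected, its size uncertain given the limit on compound 2. Compound 3 is expected to give 45000 nM, in the range 15000 nM to 130000 nM. The expected step is an at least 2.2-fold lower number from compound 2 to compound 3 (0.34 log units; beyond the scatter).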

Compound 3, half-maximal inhibitory concentration: > 100000 nM
Compound 3: no number, only a limit; the forecaster's own chance of this, stated with the estimate: 35%; middle value at least 2.2-fold (0.34 log units) from the limit.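

Hydrogen in place of methyl on this aromatic carbon gives an at least 3.0-fold higher number from compound 1 to compound 3 (0.48 log units; beyond the scatter) in this assay, so the earlier rise is not particular to methoxy. Of the three groups at this carbon, only methyl gives a number rather than a limit. The step between compound 2 and compound 3 cannot be read, so methoxy and hydrogen cannot be ranked: the limit of > 100000 nM in this assay, at which 2 of the 3 values shown sit.

Going by these compounds, it remains open how far compound 2 and compound 3 lie beyond the limit. Also open, on these data alone, is whether an ethyl group or a chlorine atom at this carbon would match methyl.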